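This account rests on a few compounds, and the source may have more. Where it says the series, first, only, none or still open, it means among the compounds named here.

Compound 1 `CN(C(=O)C1(c2ccccc2)CCCC1)C1CCCCC1`: 21000 nM
Compound 2 `CN(C(=O)C1(c2ccc(Cl)cc2)CCC1)c1ccccc1`: 24000 nM

In an ADME assay on MDCK cells (Canis lupus familiaris) for cytotoxicity (on this read-out lower numbers stand for higher toxicity in this test and higher numbers for lower toxicity in this test), compound 1 gives 21000 nM, and compound 2 gives 24000 nM. These two numbers lie within the usual scatter of one another, so neither compound can be set apart from the other on this read-out. Compound 3 `CN(C(=O)C1(c2ccccc2)CCCC1)c1ccc(Cl)cc1` has not yet been measured. It differs from compound 1 by 4-chlorophenyl in place of cyclohexyl on an amide-type nitrogen. Among the compounds with values here, no measured pair shows this particular change, so the size of the step in this assay is unknown, and no shift beyond the scatter is expected in either direction. Compound 3 is expected to give 22000 nM, within 8000 nM to 60000 nM, which would mean a 1.0-fold higher number from compound 1 to compound 3 (0.02 log units; within the scatter).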

Compound 3, half-maximal cytotoxic concentration: 20000 nM
Compound 3: middle estimate off by 1.1-fold (0.04 log units), on the high side; the range from low to high includes it.
By their numbers in this assay, from the lowest: compounds 3, 1 and 2 (each within the scatter of the next).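

On an amide-type nitrogen, 4-chlorophenyl in place of cyclohexyl gives a 1.1-fold lower number from compound 1 to compound 3 (0.02 log units; within the scatter) in this assay. An aromatic ring carrying chlorine and a non-aromatic ring of carbon only can therefore stand in this place without a shift beyond the scatter on this read-out. No supporting data bear on this result.

Still open, going by these compounds, is whether a group of a different kind in the same place, such as an amine or a carboxylic acid, would shift the read-out. A plain phenyl group there would show whether the chlorine matters.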